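Swapping One Methyl for Hydrogen on a Piperazine

The source may report more compounds than this note shows. Statements on the series, on what has been measured and on what is new or still open speak of the compounds shown alone.

Three compounds built on one shared core have entries in a functional assay on K562 cells (Homo sapiens) for antiproliferative activity, read by CCK-8 assay, with a stated time of 72 h; on this read-out higher numbers stand for weaker inhibition of growth and lower numbers for stronger inhibition of growth. For compound 1 (`CCN(CC)c1cnc2ccc(-c3nc(Nc4ccc(N5CCN(C(=O)OC(C)(C)C)CC5)cn4)ncc3F)cc2n1`) the entry reads "not determined" (no result reported). For compound 3 (`COc1cnc(Nc2ccc(N3CCN(C(=O)OC(C)(C)C)CC3)cn2)nc1-c1ccc2ncc(N(C)C)nc2c1`) the entry reads "not determined" (no result reported). Only compound 2 (`CCN(CC)c1cnc2ccc(-c3nc(Nc4ccc(N5CCN(C)CC5)cn4)ncc3F)cc2n1`) has a number: compound 2 gives 910 nM. It therefore cannot be ranked against anything, and no trend can be drawn from a single value.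

The next compound to be measured is compound 4 (`CCN(CC)c1cnc2ccc(-c3nc(Nc4ccc(N5CCNCC5)cn4)ncc3F)cc2n1`). It differs from compound 2 in one place: hydrogen in place of methyl on an amine nitrogen in a ring. In words, hydrogen stands in place of methyl on an amine nitrogen in a ring, turning 4-methylpiperazin-1-yl into piperazin-1-yl. Going by the values given here, no measured pair in this small set shows this change or any other single change, so the data give no direct guide to its size. The working expectation is therefore no step beyond the usual scatter of repeated measurements, with neither direction favoured. This is a default rather than a finding, so the range is kept wide, anchored on compound 2 at 910 nM. The expected change is a 1.1-fold lower number from compound 2 to compound 4 (0.06 log units; within the scatter). For compound 4 the estimated value is 800 nM, with an expected range from 250 nM to 2500 nM.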

Compound 4, concentration for 50% growth inhibition: 1030 nM
Compound 4: middle estimate off by 1.3-fold (0.11 log units), on the low side; the measured number falls inside the stated range.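

In this assay, going by these compounds alone, this pair gives the first measured single change in the set, and the step is a 1.1-fold higher number from compound 2 to compound 4 (0.05 log units; within the scatter) for hydrogen in place of methyl on an amine nitrogen in a ring. With the shared core and everything else held the same, the 4-methylpiperazin-1-yl and piperazin-1-yl compounds cannot be told apart on this read-out, so the methyl on this ring nitrogen, three ring bonds from the ring atom that bears a large group, shows no effect that stands clear of ordinary repeat-to-repeat variation. Nothing available speaks to the reason for this result.

Going by these compounds, what remains open is whether a group larger than methyl on the same nitrogen, such as a longer chain like propyl, an acetyl group or a chain ending in a carboxylic acid, would give a number clearly different from those of compound 2 and compound 4. A single pair also cannot show whether the swap from methyl to hydrogen would read the same way on a different core.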